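The source may report more compounds than this note shows. Statements on the series, on what has been measured and on what is new or still open speak of the compounds shown alone.

In a functional assay on HeLa cells (Homo sapiens) for cytotoxicity, read by MTT assay (on this read-out higher numbers stand for weaker inhibition and lower numbers for stronger inhibition), compound 3 `CC(C)=CC[C@@H](OCCO)C1=CC(=O)c2c(O)ccc(O)c2C1=O` gives 18600 nM and compound 2 `CC(C)=CC[C@@H](OC(=O)C1CCCO1)C1=CC(=O)c2c(O)ccc(O)c2C1=O` gives 17000 nM, so the two stand level within the scatter. Compound 1 `CCCCCCC(C)(O)CC(=O)O[C@H](CC=C(C)C)C1=CC(=O)c2c(O)ccc(O)c2C1=O` reaches only a limit of the assay, > 100000 nM.

Compound 4 `CCCCC(C)(O)CC(=O)O[C@H](CC=C(C)C)C1=CC(=O)c2c(O)ccc(O)c2C1=O` carries (2-hydroxy-2-methylhexyl)carbonyl in place of 2-hydroxyethyl on an oxygen on a saturated carbon.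

Within the data shown here, two measured steps bear on this change. Oxolan-2-yl in place of 2-hydroxy-2-methyloctyl on a carbonyl carbon gave an at least 5.8-fold lower number from compound 1 to compound 2 (0.76 log units; beyond the scatter), while 2-hydroxyethyl in place of (oxolan-2-yl)carbonyl gave a 1.1-fold higher number from compound 2 to compound 3 (0.04 log units; within the scatter). The closest measured counterpart of the entering group is therefore the 2-hydroxy-2-methyloctyl of compound 1, and the first step, read in reverse, sets the direction towards a higher number and weaker inhibition. Among the measured compounds shown here, with only this one step as a guide, a modest move is expected rather than a full return to a limit, though a limit remains possible.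

The expected size is a 2.4-fold higher number from compound 3 to compound 4 (0.38 log units; beyond the scatter).

For compound 4 the estimated value is 45000 nM, with an expected range of 15000 nM to 130000 nM.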

Compound 4, half-maximal inhibitory concentration: 60600 nM
Compound 4: middle estimate off by 1.3-fold (0.13 log units), on the low side, within the range that was stated.
By their numbers in this assay, from the lowest: compounds 2 and 3 (each within the scatter of the next); then compound 4. At a limit, above all of these: compound 1.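

With (2-hydroxy-2-methylhexyl)carbonyl in place of 2-hydroxyethyl on an oxygen on a saturated carbon, inhibition weakens beyond the scatter, a 3.3-fold higher number from compound 3 to compound 4 (0.51 log units; beyond the scatter). Among these compounds, the comparison with the other short group points the same way, a 3.6-fold higher number from compound 2 to compound 4 (0.55 log units; beyond the scatter), so 2-hydroxy-2-methylhexyl on a carbonyl carbon is the first measured chain in this position to give a number rather than a limit, yet it remains weaker than oxolan-2-yl. The change from the longer chain, an at least 1.6-fold lower number from compound 1 to compound 4 (0.21 log units; that floor lies within the scatter), gives only a floor that does not separate the two chains, and the value of compound 1 is a limit: the limit of > 100000 nM in this assay, at which 1 of the 4 values shown sits.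

Open, going by these compounds, is how a chain shorter than 2-hydroxy-2-methylhexyl would read on this carbonyl carbon. Also open, on these data alone, is whether an amine or a carboxylic acid in place of the chain's hydroxyl would move the number, and in which direction.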